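Triazolyl in place of tetrazolyl on a salicylic core

The compounds below may be only part of what the source reports. "The series", "measured", "known", "first", "only" and "open" are said of these compounds alone.

Measured so far:
compound 1, `CC(=O)Oc1ccc(-n2cccc2)cc1C(=O)O` — 42 mg/kg
compound 2, `O=C(O)c1cc(C2N=NN=N2)ccc1O` — 110 mg/kg
compound 3, `O=C(O)c1cc(-c2ccncn2)ccc1O` — a limit, > 200 mg/kg

In a functional assay on the whole organism for inhibition, with Rattus norvegicus as the target, read by paw edema (a lower number here means that less compound is needed, a higher number that more compound is needed for the effect), compound 2 gives 110 mg/kg. Of the two numbers shown, this is the higher one; compound 1 gives 42 mg/kg, a lower number, and the gap between the two lies beyond the usual scatter. For compound 3 this assay reports only a limit, > 200 mg/kg, and no number. Going by the values given here, none of these three compounds differs from another in a single place, so no measured step is available to guide the next change.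

Compound 4 `O=C(O)c1cc(-n2cncn2)ccc1O` has not yet been measured. It differs from compound 2 in one place (a group of 5 heavy atoms (2 carbon, 3 nitrogen; one five-membered aromatic ring with 3 hetero atoms) in place of a group of 5 heavy atoms (1 carbon, 4 nitrogen; one five-membered non-aromatic ring with 4 hetero atoms), on an aromatic carbon). Among the compounds with values here, with no measured step of this kind to lean on, the move from compound 2 to compound 4 is expected to be small, either toward a higher number or none beyond the scatter. Compound 4 is estimated at 150 mg/kg, within a range of 60 mg/kg to 400 mg/kg. This corresponds to an expected step of a 1.4-fold higher number from compound 2 to compound 4 (0.13 log units; within the scatter).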

Compound 4, dose for half-maximal effect: 200 mg/kg
Compound 4: middle estimate off by 1.3-fold (0.12 log units), on the low side, within the range that was stated.
By their numbers in this assay, from the lowest: compound 1; then compounds 2 and 4 (each within the scatter of the next).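

In this assay, going by these compounds alone, the exchange of the five-membered non-aromatic ring with 4 hetero atoms for 1H-1,2,4-triazol-1-yl, para to a hydroxy group and meta to a carboxy group, gives the first measured step at this position: a 1.8-fold higher number from compound 2 to compound 4 (0.26 log units; within the scatter). On this step the two rings cannot be told apart in this assay, although one is aromatic and the other is not. Compound 3, which carries a different ring at the same place, is reported only as a limit: the limit of > 200 mg/kg in this assay, at which 1 of the 4 values shown sits.

Whether any group at this position can shift the number beyond the scatter remains open, and an amine or a carboxylic acid there lies outside the compounds shown. Compound 1 gives 42 mg/kg but differs from the others in more than one place, so which of its differences matters cannot be read.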